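Benzyl-triazole series: replacing tert-butyl with methoxy

A few compounds are considered here, and "the series" means these few. Any claim that something is new, unique, unknown or untested is made for them only; others in the source may bear on it.

Measured so far:
compound 1 `Cc1cccc(Cn2cc(COc3ccc4c(=O)ccoc4c3)nn2)c1` — 16000 nM
compound 2 `CC(C)(C)c1ccc(Cn2cc(COc3ccc4c(=O)ccoc4c3)nn2)cc1` — > 100000 nM

In a functional assay on MDA-MB-231 cells (Homo sapiens) for cytotoxicity, read by MTT assay, with a stated time of 48 h (on this read-out higher numbers stand for weaker inhibition and lower numbers for stronger inhibition), compound 1 gives 16000 nM. Compound 2 returns only a limit in this assay, > 100000 nM, so no number is known for it; this is the limit of > 100000 nM in this assay, at which 1 of the 2 values shown sits, at which one of the two values shown sits. Compound 2 therefore stands at the weak end of the numbers shown, and the two measured compounds cannot be compared as a step.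

Compound 3 `COc1ccc(Cn2cc(COc3ccc4c(=O)ccoc4c3)nn2)cc1` has not yet been measured in this assay. It differs from compound 2 as follows: methoxy in place of tert-butyl on an aromatic carbon. Among the measured compounds shown here, no step between measured compounds is available for this change, so the expectation rests only on the two values shown. The step from compound 2 to compound 3 is expected to be an at least 3.3-fold lower number from compound 2 to compound 3 (0.52 log units; beyond the scatter), moving towards stronger inhibition, though a limit result for compound 3 remains possible. Compound 3 is estimated to give 30000 nM in this assay, with a range from 10000 nM to 100000 nM.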

Compound 3, half-maximal inhibitory concentration: > 100000 nM
Compound 3 ended at the assay's limit; the forecaster's own chance of this, stated with the estimate: 35%; middle value at least 3.3-fold (0.52 log units) from the limit.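

In this assay compound 3 returns only a limit, and it is the same limit that compound 2 holds: the limit of > 100000 nM in this assay, at which 2 of the 3 values shown sit. With both compounds at a limit, the step for methoxy in place of tert-butyl on an aromatic carbon cannot be read, and neither group at this place gives a number in the assay's range. Among the compounds shown here, the one readable comparison is an at least 6.2-fold higher number from compound 1 to compound 3 (0.79 log units; beyond the scatter), a move towards weaker inhibition for 4-methoxyphenyl in place of 3-methylphenyl, which adds a second compound on the weak side of the only compound with a number.

The compounds shown leave open whether the group or its place on the ring accounts for that step, as 3-methylphenyl and 4-methoxyphenyl differ in both. They also leave open whether an amine or a carboxylic acid on the same aromatic carbon would return a number rather than a limit in this assay.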